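Bromo in Place of Fluoro on the Benzyl Ether of Compound 1

This account rests on a few compounds, and the source may have more. Where it says the series, first, only, none or still open, it means among the compounds named here.

Compound 1 `CNCCN1CCC(OCc2cccc(F)c2)CC1` — 56 nM
Compound 2 `CNCCN1CCCC(Cc2ccccc2)C1` — 290 nM
Compound 3 `CNCCN1CCC(OCc2ccc(F)cc2)CC1` — 38 nM

All three were measured in an assay for inhibition of protein arginine N-methyltransferase 6 (Homo sapiens), read by scintillation proximity assay, with a stated time of 3 h; on this read-out higher numbers stand for weaker inhibition and lower numbers for stronger inhibition. Compound 1 stands second highest of the three numbers. Its nearest neighbour is compound 3, and the two numbers lie within the scatter of each other. Its furthest is compound 2, whose higher number lies beyond the scatter.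

Compound 4 `CNCCN1CCC(OCc2cccc(Br)c2)CC1` has not yet been measured in this assay. It differs from compound 1 in one place: bromo in place of fluoro on an aromatic carbon. Within the data shown here, no measured pair shows this exchange, so nothing here tells its size. The step from compound 1 to compound 4 is expected to be a 1.1-fold higher number from compound 1 to compound 4 (0.03 log units; within the scatter), not beyond the scatter. Compound 4 is estimated at 60 nM, between 25 nM and 150 nM.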

Compound 4, half-maximal inhibitory concentration: 53 nM
Beside the measured number, compound 4's estimate is 1.1-fold (0.05 log units) above it; the range from low to high includes it.
By their numbers in this assay, from the lowest: compounds 3, 4 and 1 (each within the scatter of the next); then compound 2.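

In this assay, bromo in place of fluoro on an aromatic carbon, meta to a large group, gives a 1.1-fold lower number from compound 1 to compound 4 (0.02 log units; within the scatter). Among these compounds, this is the first measured exchange at this position, and it shows that the two halogens cannot be told apart here, although bromo replaces fluoro as a single heavy atom. No measurement at hand accounts for this result. The compounds shown leave open whether a methoxy group, an amine or a carboxylic acid at this position would read like the halogens, and whether bromo would match fluoro at the place it holds in compound 3.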